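The source may report more compounds than this note shows. Statements on the series, on what has been measured and on what is new or still open speak of the compounds shown alone.

Of the compounds shown here, two of a shared core have been tested in a functional assay on SK-N-SH cells (Homo sapiens) for cytotoxicity, read by sulforhodamine B assay, with a stated time of 48 h; a lower number here means a stronger inhibitor, a higher number a weaker inhibitor. Compound 1, with the structure `CO[C@@H]1CC=C2NN(c3ccccn3)C(=O)CC[C@]2(c2ccccc2)O1`, gives 2100 nM in this assay. Compound 2, with the structure `CO[C@@H]1CC=C2N(c3ccccn3)C(=O)C[C@]2(c2ccccc2)O1`, gives 5100 nM in this assay. Within the data shown here, of the two numbers so far, compound 2 has the higher one, so it is the weaker inhibitor of the pair, and the gap between it and compound 1 is larger than the usual scatter of repeated measurements. The two structures differ in more than one place, so nothing is read from that gap beyond what the two values themselves show.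

Compound 3, with the structure `CO[C@@H]1CC=C2N(c3cc(Cl)cc(Cl)c3)C(=O)C[C@]2(c2ccccc2)O1`, has not yet been measured. It differs from compound 2 in one place: 3,5-dichlorophenyl in place of pyridin-2-yl on an amide-type nitrogen in a ring. Among the measured compounds shown here, no measured pair shows what this kind of exchange does on this core, so the direction of the change is open. The expected step from compound 2 to compound 3 is small, a 1.3-fold lower number from compound 2 to compound 3 (0.11 log units; within the scatter), within or barely beyond the scatter. For compound 3 the estimated value in this assay is 4000 nM, with a range from 1500 nM to 12000 nM.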

Compound 3, half-maximal inhibitory concentration: 9670 nM
Compound 3: the middle estimate sits 2.4-fold (0.38 log units) below what was measured; the measured number falls inside the stated range.
By their numbers in this assay, from the lowest: compound 1; then compounds 2 and 3 (each within the scatter of the next).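

In this assay, the exchange of pyridin-2-yl for 3,5-dichlorophenyl on the amide-type nitrogen gives a 1.9-fold higher number from compound 2 to compound 3 (0.28 log units; within the scatter), so this read-out does not separate the two compounds. Among these compounds, this is the first pair on the shared core that differs in only one place, and it shows that two quite different aromatic rings on this nitrogen give values within the scatter of each other: one has 6 heavy atoms, including a ring nitrogen and 1 hydrogen-bond acceptor, and the other has 8 heavy atoms, including two chlorines and no acceptor. No accompanying measurement offers an explanation for this result.

The ring nitrogen left and the two chlorines entered in the same step, so plain phenyl or 3-chlorophenyl on this nitrogen would be needed to tell their contributions apart. Both groups seen here are aromatic rings, which leaves open what a non-aromatic group at this position, such as cyclohexyl or a longer alkyl chain, or a phenyl ring carrying an amine or a carboxylic acid, would give.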